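From naphthalen-2-yl to 4-methylphenyl on an aromatic nitrogen

The compounds below may be only part of what the source reports. "The series", "measured", "known", "first", "only" and "open" are said of these compounds alone.

Compound 1 `CC1OC2(C=CC(=O)C=C2)N(c2nc(-c3ccc4ccccc4c3)nn2-c2ccc3ccccc3c2)C1=O`: 60 nM
Compound 2 `O=C1C=CC2(C=C1)OCC(=O)N2c1nc(-c2ccc3c(c2)OCCO3)nn1-c1ccccc1`: 100 nM
Compound 3 `O=C1C=CC2(C=C1)OCC(=O)N2c1nc(-c2ccc3ccccc3c2)nn1-c1ccc2ccccc2c1`: 50 nM

In a functional assay on MDA-MB-231 cells (Homo sapiens) for antiproliferative activity, with a stated time of 5 days (a lower number here means a stronger inhibitor, a higher number a weaker inhibitor), compound 1 gives 60 nM, which lies within the usual scatter of both other compounds, so these numbers support no ranking. Compound 4 `Cc1ccc(-n2nc(-c3ccc4ccccc4c3)nc2N2C(=O)C(C)OC23C=CC(=O)C=C3)cc1` has 4-methylphenyl in place of naphthalen-2-yl on an aromatic nitrogen. Going by the values given here, the one measured step, a 1.2-fold lower number from compound 1 to compound 3 (0.08 log units; within the scatter), concerns a saturated ring carbon instead, so it says little about this change. Compound 2 also has one six-membered aromatic ring of carbon only on that nitrogen, differs elsewhere too, and gives 100 nM. On that value, a small rise in the number is expected, possibly no larger than the scatter. The expected step is a 1.7-fold higher number from compound 1 to compound 4 (0.22 log units; within the scatter). For compound 4 the estimate is 100 nM, with an expected range of 40 nM to 250 nM.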

Compound 4, half-maximal inhibitory concentration: 100 nM
The estimate for compound 4 equals the measured number at the digits printed, and the stated range covers the measured number.
By their numbers in this assay, from the lowest: compounds 3, 1, 2 and 4 (each within the scatter of the next).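

In this assay, this first measured change on the aromatic nitrogen gives a 1.7-fold higher number from compound 1 to compound 4 (0.22 log units; within the scatter), so the two compounds cannot be told apart. For this pair, then, replacing naphthalen-2-yl, with its 2 six-membered aromatic rings, by 4-methylphenyl, with one, leaves the number within the scatter. Nothing shown gives a measured reason for this result. Still open, from the compounds shown here alone, is how an amine or a carboxylic acid on this nitrogen's phenyl ring would read. Also open, going by these compounds, is whether 4-methylphenyl behaves the same way on the core of compound 3.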